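The source may report more compounds than this note shows. Statements on the series, on what has been measured and on what is new or still open speak of the compounds shown alone.

Compound 1 `Cc1ccc(C2=NN(c3nc(-c4ccc([N+](=O)[O-])cc4)cs3)C(c3ccc(F)cc3)C2)s1` and compound 2 `Cc1ccc(C2=NN(c3nc(-c4ccc(S(C)(=O)=O)cc4)cs3)C(c3ccc(F)cc3)C2)s1` share one core and differ only in the group on the phenyl ring attached to the thiazole. In a functional assay on A549 cells (Homo sapiens) for antiproliferative activity, read by XTT assay, with a stated time of 24 h (on this read-out lower numbers stand for stronger inhibition and higher numbers for weaker inhibition), compound 1 gives 16.7 ug/mL. Compound 2 reaches only the limit of this assay at > 500 ug/mL, so its place on the scale is known as a limit and not as a number. The step of an at least 29-fold higher number from compound 1 to compound 2 (1.47 log units; beyond the scatter) is therefore read against (the limit of > 500 ug/mL in this assay, at which 1 of the 2 values shown sits). Compound 3 `Cc1ccc(C2=NN(c3nc(-c4ccc(C(F)(F)F)cc4)cs3)C(c3ccc(F)cc3)C2)s1` has not yet been measured in this assay. It differs from compound 2 by trifluoromethyl in place of methylsulfonyl on an aromatic carbon. For the measured compounds named here, only the one measured step, from nitro to methylsulfonyl, bears on this change, and it was large; no measured step covers trifluoromethyl itself. Compound 3 is expected to lie somewhere between the two measured compounds, with an estimated step of an at least 5.0-fold lower number from compound 2 to compound 3 (0.69 log units; beyond the scatter). Compound 3 is estimated at 100 ug/mL, within a range from 15 ug/mL to 500 ug/mL.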

Compound 3, half-maximal inhibitory concentration: > 500 ug/mL
Compound 3 ended at the assay's limit; the forecaster's own chance of this, stated with the estimate: 35%; at least 5.0-fold (0.69 log units) between middle value and limit.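

Changing nitro to trifluoromethyl on this aromatic carbon gives an at least 29-fold higher number from compound 1 to compound 3 (1.47 log units; beyond the scatter) in this assay, so the large loss seen with methylsulfonyl also appears with a group that shares neither its sulfur nor its oxygen atoms. Of the three groups shown on this carbon, nitro alone gives a readable value, with compound 1 at 16.7 ug/mL. The step from methylsulfonyl to trifluoromethyl cannot be read, because both of those compounds give only a limit and not a number: the limit of > 500 ug/mL in this assay, at which 2 of the 3 values shown sit.

The compounds shown leave open whether the two limits hide any difference between methylsulfonyl and trifluoromethyl. They also leave open whether any group other than nitro on this carbon, such as an amine, a nitrile or a carboxylic acid, would give a readable value in this assay.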